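Dichloro for chloro-trifluoromethyl on the aryl urea

The source may report more compounds than this note shows. Statements on the series, on what has been measured and on what is new or still open speak of the compounds shown alone.

Measured so far:
compound 1 `COc1cc2cc(Oc3ccc(NC(=O)Nc4cccc(C(F)(F)F)c4)cc3)c(C)nc2cc1OC`: 32400 nM
compound 2 `COc1cc2cc(Oc3ccc(NC(=O)Nc4ccc(Cl)c(C(F)(F)F)c4)cc3)c(C)nc2cc1OC`: 12200 nM

In a functional assay on NCI-H522 cells (Homo sapiens) for inhibition, read by sulforhodamine B assay, with a stated time of 48 h (on this read-out lower numbers stand for higher toxicity in this test and higher numbers for lower toxicity in this test), compound 2 gives the lowest of the two numbers; its nearest neighbour is compound 1, and the step of a 2.7-fold lower number from compound 1 to compound 2 (0.42 log units; beyond the scatter) lies beyond the scatter. That step, chloro in place of hydrogen on an aromatic carbon, is the only measured one and is modest in size.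

Compound 3 `COc1cc2cc(Oc3ccc(NC(=O)Nc4ccc(Cl)c(Cl)c4)cc3)c(C)nc2cc1OC` follows from compound 2 by chloro in place of trifluoromethyl on an aromatic carbon. Among the measured compounds shown here, the change sits on an aromatic carbon ortho to a chloro group and meta to a large group, and no measured pair exchanges trifluoromethyl for chloro, so the step from compound 1 to compound 2 bears on it only loosely: it shows that a single halogen on this ring can move the number by a modest amount. With nothing closer to go by, compound 3 is expected to stay near compound 2 in this assay, the estimated step being a 1.2-fold higher number from compound 2 to compound 3 (0.09 log units; within the scatter), with no direction beyond the scatter claimed. Compound 3 is therefore estimated at 15000 nM, within a range from 6000 nM to 40000 nM.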

Compound 3, concentration lethal to 50% of the cells: 59500 nM
Compound 3: the middle estimate sits 4.0-fold (0.60 log units) below what was measured; measured number above the stated range.
By their numbers in this assay, from the lowest: compound 2; then compounds 1 and 3 (each within the scatter of the next).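

In this assay, this position proves sensitive to which group it carries when a chloro group stands ortho to it: trifluoromethyl cannot be exchanged for chloro without consequence, as a 4.9-fold higher number from compound 2 to compound 3 (0.69 log units; beyond the scatter) shows. The other step, a 1.8-fold higher number from compound 1 to compound 3 (0.26 log units; within the scatter), leaves 3,4-dichlorophenyl and 3-(trifluoromethyl)phenyl indistinguishable on this read-out, so among these three compounds the lower number belongs only to the 4-chloro-3-(trifluoromethyl)phenyl urea of compound 2, and neither the added chloro nor the trifluoromethyl carries it in every setting. Nothing shown bears on the reason for this difference.

From the compounds shown here alone, whether a bromo, a methyl or a nitrile at this position would keep the number of compound 2 or fall in with compound 3 stays open, as does the result for a lone chloro group with hydrogen at this position. Going by these compounds, all three compounds also share one core and one cell line, so it remains open whether the exchange of trifluoromethyl for chloro would behave the same way elsewhere.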